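Chloro in Place of Hydrogen on a Bromo Benzamide

This account rests on a few compounds, and the source may have more. Where it says the series, first, only, none or still open, it means among the compounds named here.

Compound 1 `COc1c(Br)cc(Br)cc1C(=O)Nc1ccccc1`: > 100000 nM
Compound 2 `O=C(Nc1ccccc1)c1cc(Br)cc(Br)c1O`: > 100000 nM

In an assay on isolated protein for inhibition of thiosulfate sulfurtransferase (Homo sapiens), with a stated time of 60 min, in the absence of a further agent (on this read-out lower numbers stand for stronger inhibition and higher numbers for weaker inhibition), compound 1 gives only a limit, > 100000 nM. Compound 2 also gives only a limit, > 100000 nM. The step that the two limits leave unreadable from compound 1 to compound 2 is therefore unreadable. Compound 3 `COc1c(Br)cc(Br)cc1C(=O)Nc1cccc(Cl)c1` has not yet been measured; it differs from compound 1 by chloro in place of hydrogen on an aromatic carbon. Among the measured compounds shown here, no measured step bears on this change, as the only measured step is unreadable and both values sit at the limit of > 100000 nM in this assay, at which 2 of the 2 values shown sit. Compound 3 is expected to stay near that limit, with an estimated 150000 nM (range 40000 nM to 600000 nM). The expected step that the limit leaves unreadable from compound 1 to compound 3 is thus estimated to lie within the scatter.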

Compound 3, half-maximal inhibitory concentration: > 100000 nM
Compound 3: a limit, no number; the forecaster's own chance of this, stated with the estimate: 80%; the middle value does not contradict the limit.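

Among the compounds shown here, compound 3 gives only a limit, > 100000 nM, and compound 1 also gives only a limit, so no step between them can be read: the limit of > 100000 nM in this assay, at which 3 of the 3 values shown sit.

The compounds shown leave open how strongly any of them inhibits the enzyme, and what chloro in place of hydrogen changes.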